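Methyl for Hydrogen on the Amine Nitrogen of Compound 3

The source may report more compounds than this note shows. Statements on the series, on what has been measured and on what is new or still open speak of the compounds shown alone.

Four compounds share one core carrying an amine on an aromatic ring. Compound 1, `c1cnc2ccc(-c3ccc4oc(NC5CCCCC5)nc4c3)cc2c1`, gives > 1000 nM in an assay on HEK293 cells for inhibition of Fatty-acid amide hydrolase 1 (Homo sapiens), read by fluorescence (a higher number here means a weaker inhibitor, a lower number a stronger inhibitor), which is a limit of the method and not a number. That reading is the limit of > 1000 nM in this assay, at which 1 of the 3 values shown sits. Compound 2, `Cn1ncc2cc(-c3ccc4oc(NC5CCCCC5)nc4c3)ccc21`, gives 61 nM in this assay. Compound 3, `Cn1ccc2cc(-c3ccc4oc(Nc5ccccc5)nc4c3)ccc21`, gives 48 nM in this assay; this is the lower of the two numbers recorded, yet compound 2 sits within the usual scatter of it, so the two cannot be separated. Compound 4, `CN(c1ccccc1)c1nc2cc(-c3ccc4c(ccn4C)c3)ccc2o1`, has not yet been measured. It differs from compound 3 in one place: methyl in place of hydrogen on a nitrogen on an aromatic ring, so the anilino becomes methyl(phenyl)amino. For the measured compounds named here, no measured pair shows this change, so nothing here tells its size. The expected step of a 3.1-fold higher number from compound 3 to compound 4 (0.49 log units; beyond the scatter) points toward a somewhat weaker inhibitor, though a result within the scatter would not surprise. Compound 4 is therefore estimated at 150 nM in this assay, within a range from 40 nM to 800 nM.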

Compound 4, half-maximal inhibitory concentration: 68 nM
The estimate for compound 4 lay 2.2-fold (0.34 log units) above the measured number; the range from low to high includes it.
By their numbers in this assay, from the lowest: compounds 3, 2 and 4 (each within the scatter of the next). At a limit, above all of these: compound 1.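

In this assay, for the compounds shown here, this pair gives the first direct reading of a change at this nitrogen, and it shows a 1.4-fold higher number from compound 3 to compound 4 (0.15 log units; within the scatter) for methyl in place of hydrogen. The hydrogen on this nitrogen on an aromatic ring can therefore be replaced, turning anilino into methyl(phenyl)amino, with no difference between compound 3 and compound 4 that this measurement can resolve. What the two numbers cannot show is why the change has so little effect, as nothing measured here bears on that question.

Going by these compounds, it remains open whether a longer chain on this nitrogen, such as ethyl or propyl, or an acetyl group, would leave the number just as unmoved. On these data alone, it is also open whether the same methyl change would read the same way on compound 2, whose amine carries a different group.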